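Methyl position on the benzyl arm: compound 3 to compound 4

The source may report more compounds than this note shows. Statements on the series, on what has been measured and on what is new or still open speak of the compounds shown alone.

The series shares the core seen in compound 1 `CCC(CC)Nc1cc(C)nc2c(-c3cnc(N(C)C)cc3C)c(C)nn12`, which in an assay on CHO cells for binding affinity to corticotropin-releasing factor receptor 1 (Homo sapiens) (a lower number here means a stronger inhibitor, a higher number a weaker inhibitor), gives 9.4 nM. Among the compounds with values here, compound 2 `CCCN(CC1CC1)c1cc(C)nc2c(-c3cnc(N(C)C)cc3C)c(C)nn12` gives 2.6 nM in this assay, and a 3.6-fold lower number from compound 1 to compound 2 (0.56 log units; beyond the scatter) is the one measured change within the set. Compound 3 `CCN(Cc1ccccc1C)c1cc(C)nc2c(-c3cnc(N(C)C)cc3C)c(C)nn12` gives 2.4 nM, the lowest number among the three; compound 2 sits within the scatter of it, while compound 1 lies beyond the scatter, with the higher number.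

Compound 4 `CCN(Cc1ccc(C)cc1)c1cc(C)nc2c(-c3cnc(N(C)C)cc3C)c(C)nn12` is not yet measured. It differs from compound 3 by 4-methylphenyl in place of 2-methylphenyl on a saturated chain carbon bound to a nitrogen on an aromatic ring. The only measured step, a 3.6-fold lower number from compound 1 to compound 2 (0.56 log units; beyond the scatter), exchanges the whole amino substituent and says nothing about where a methyl sits on the aryl part of that substituent; no pair shown isolates such a move, and the atoms stay the same, only rejoined. The expected step is therefore a 1.3-fold higher number from compound 3 to compound 4 (0.10 log units; within the scatter), nothing beyond the scatter. The estimate for compound 4 in this assay is 3 nM, with a range from 1.2 nM to 8 nM.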

Compound 4, inhibition constant: 2.3 nM
Beside the measured number, compound 4's estimate is 1.3-fold (0.12 log units) above it; the range from low to high includes it.
By their numbers in this assay, from the lowest: compounds 4, 3 and 2 (each within the scatter of the next); then compound 1.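

In this assay, 4-methylphenyl in place of 2-methylphenyl gives a 1.0-fold lower number from compound 3 to compound 4 (0.02 log units; within the scatter) and stays within the scatter, so on this benzyl arm the two methyl placements cannot be told apart. This pair isolates the methyl position on the aryl part of the amino substituent, a question that a 3.6-fold lower number from compound 1 to compound 2 (0.56 log units; beyond the scatter) could not address as it exchanges the whole substituent. No available evidence bears on this result.

From the compounds shown here alone, whether the methyl itself contributes to the number remains open, and an unsubstituted benzyl, or a methoxy group or chlorine in place of the methyl, would test that on this arm. Also open, going by these compounds, is how much the ethyl group on the same nitrogen tolerates change, for instance a longer chain such as butyl.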